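Dichlorophenyl for Methoxyphenyl in a Series Without Measurable Inhibition

The source may report more compounds than this note shows. Statements on the series, on what has been measured and on what is new or still open speak of the compounds shown alone.

Compound 1 `Cn1c(Cc2nn(C)c(=O)c3ccccc23)nnc1SCC(=O)Nc1ccc(I)cc1`: "not active" (no number reported)
Compound 2 `CCCOc1ccc(NC(=O)CSc2nnc(Cc3nn(C)c(=O)c4ccccc34)n2C)cc1`: > 30000 nM
Compound 3 `COc1ccc(NC(=O)CSc2nnc(Cc3nn(C)c(=O)c4ccccc34)n2C)cc1`: "not active" (no number reported)

Of the compounds shown here, three sharing one core have been tested in an assay on isolated protein (Mus musculus) for inhibition of IL15-IL15 receptor (Homo sapiens), read by resazurin assay, with stated times of 30 min and 2.5 days; a higher number here means a weaker inhibitor, a lower number a stronger inhibitor. Compound 3 has no single number there: its entry reads "not active" (no number reported). Compound 1 likewise carries no number, being reported as "not active" (no number reported). Compound 2 is reported only as a limit of the assay, > 30000 nM, and this is the one entry sitting at the limit of > 30000 nM in this assay, at which 1 of the 3 values shown sits. Among the compounds with values here, compound 3 therefore stands among three results, none of which gives a measured inhibitory concentration, and no step between two measured compounds can be computed.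

Compound 4 `Cn1c(Cc2nn(C)c(=O)c3ccccc23)nnc1SCC(=O)Nc1ccc(Cl)cc1Cl` has not yet been measured in this assay. It differs from compound 3 in one place: 2,4-dichlorophenyl in place of 4-methoxyphenyl on an amide-type nitrogen. Since none of the three results gives a number to move from, no step beyond the usual scatter can be expected in either direction; compound 4 is expected to remain where compound 3 and compound 2 stand, most likely as a limit rather than a number.

Compound 4 is estimated in this assay at 50000 nM, within a range from 10000 nM to 300000 nM.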

Compound 4, half-maximal inhibitory concentration: 17300 nM
Compound 4: middle estimate off by 2.9-fold (0.46 log units), on the high side, within the range that was stated.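

Compound 4 gives this series its first measured inhibitory concentration in this assay: with 2,4-dichlorophenyl on the amide-type nitrogen, compound 4 reads 17300 nM, whereas the entry for the 4-methoxyphenyl of compound 3 reads "not active", so a change at this one position separates a reported number from an entry without one. Against the 4-propoxyphenyl group, which gives only a limit of the assay, the values show an at least 1.7-fold lower number from compound 2 to compound 4 (0.23 log units; that floor lies within the scatter), and this step therefore does not establish that 2,4-dichlorophenyl gives the stronger inhibition of the two. Steps from compound 1 and from compound 3 cannot be read, since neither entry carries a number.

The compounds shown leave open whether both chlorine atoms are needed for a measurable value, as no compound here carries a single chlorine on this phenyl ring. They also leave open how an amine or a carboxylic acid on this ring would read, and whether any group at this position can bring the number far below that of compound 4.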